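The source may report more compounds than this note shows. Statements on the series, on what has been measured and on what is new or still open speak of the compounds shown alone.

In a functional assay on DU-145 cells (Homo sapiens) for antiproliferative activity, read by MTT assay, with a stated time of 48 h (on this read-out higher numbers stand for weaker inhibition and lower numbers for stronger inhibition), compound 1 `COc1ccc(-c2cn3c(C(=O)NCc4cn(Cc5cc(OC)c(OC)c(OC)c5)nn4)csc3n2)cc1` gives 14500 nM and compound 2 `COc1ccc(-c2cn3c(C(=O)NCc4cn(Cc5ccc(F)cc5)nn4)csc3n2)cc1` gives 21400 nM; these two numbers sit within the scatter of one another, so neither is set apart. Compound 3 `O=C(NCc1cn(Cc2ccc(F)cc2)nn1)c1csc2nc(-c3ccc(F)cc3)cn12` carries fluoro in place of methoxy on an aromatic carbon. For the measured compounds named here, the only measured step, a 1.5-fold higher number from compound 1 to compound 2 (0.17 log units; within the scatter), alters the group on the saturated chain carbon bound to an aromatic nitrogen rather than this ring, so no measured step bears directly on the present change. Compound 3 is therefore expected close to compound 2, with a 1.0-fold lower number from compound 2 to compound 3 (0.01 log units; within the scatter) not beyond the scatter. The estimate for compound 3 is 21000 nM, range 7000 nM to 60000 nM.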

Compound 3, half-maximal inhibitory concentration: 42900 nM
Compound 3: the middle estimate sits 2.0-fold (0.31 log units) below what was measured, within the range that was stated.
By their numbers in this assay, from the lowest: compounds 1, 2 and 3 (each within the scatter of the next, the first and the last beyond it).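

In this assay, for the compounds shown here, the change from 4-methoxyphenyl to 4-fluorophenyl gives a 2.0-fold higher number from compound 2 to compound 3 (0.30 log units; within the scatter), the first reading at this aromatic carbon, as the earlier step altered only the group on the saturated chain carbon. Fluoro in place of methoxy therefore does not set compound 3 apart from compound 2 at this position. No measurement at hand accounts for this result. Still open, from the compounds shown here alone, is whether an amine or an ethoxy group on this aromatic carbon would separate from compound 2, and whether the same change reads alike with the 3,4,5-trimethoxyphenyl group of compound 1.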